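Removing One Methoxy Group From a Cytotoxic Compound

The compounds below may be only part of what the source reports. "The series", "measured", "known", "first", "only" and "open" are said of these compounds alone.

Within the data shown here, in a functional assay on CNE-2 cells (Homo sapiens) for cytotoxicity, read by sulforhodamine B assay, with a stated time of 48 h (a lower number here means a stronger inhibitor, a higher number a weaker inhibitor), compound 1 `COc1ccc(/C=C/C(=O)c2ccc(N)c(-c3ccc(F)cc3)c2)cc1O` stands as "not determined" (no result reported), so compound 2 `COc1cc(/C=C/C(=O)c2ccc(N)c(-c3ccc(F)cc3)c2)cc(OC)c1OC`, at 4600 nM, supplies the only number and has nothing to be ranked against. Compound 3 `COc1ccc(/C=C/C(=O)c2ccc(N)c(-c3ccc(F)cc3)c2)cc1OC` differs from compound 2 in one place: hydrogen in place of methoxy on an aromatic carbon, with hydrogen in place of methoxy on an aromatic carbon. Among the measured compounds shown here, no measured pair shows what this change does, so any forecast is uncertain. The expected step of a 1.3-fold higher number from compound 2 to compound 3 (0.12 log units; within the scatter) is small, leaning towards weaker inhibition, and may not exceed the usual scatter. For compound 3 the estimated value is 6000 nM, with an expected range from 2000 nM to 20000 nM.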

Compound 3, half-maximal inhibitory concentration: 3510 nM
Estimate against measurement, compound 3: 1.7-fold (0.23 log units) above; the measured number falls inside the stated range.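

Among these compounds, exchanging this methoxy group for hydrogen in this assay gives a 1.3-fold lower number from compound 2 to compound 3 (0.12 log units; within the scatter) and provides the first measured pair for this change. At this place on the ring, ortho to a methoxy group, the loss of the methoxy group therefore leaves no difference beyond the usual spread of repeated measurements. No available evidence bears on why this is so.

As far as these compounds go, what an amine, a chlorine atom or a longer chain such as ethoxy would do at this place remains open. So does the effect of removing the other methoxy group on this ring.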